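One More Fluoro on a Compound at the Limit

The source may report more compounds than this note shows. Statements on the series, on what has been measured and on what is new or still open speak of the compounds shown alone.

Compound 1 (`O=C(Nc1ccc2sc(-c3ccccc3)nc2c1)c1cccs1`) reads > 50 uM in an ADME assay on HepG2 cells (Homo sapiens) for inhibition, read by resazurin assay, with a stated time of 48 h (a lower number here means that less compound is needed, a higher number that more compound is needed for the effect), as a limit, not a number. Compound 2 (`O=C(Nc1ccc2sc(-c3ccccc3F)nc2c1)N1CCCC1`) reads > 50 uM as a limit too. Compound 3 (`O=C(Nc1ccc2sc(-c3ccccc3F)nc2c1)N1CCCCC1`) reads > 50 uM as a limit as well. Compound 2 therefore has no number of its own, and the two other values beside it are limits too. What all three share is the limit of > 50 uM in this assay, at which 3 of the 3 values shown sit, and nothing finer.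

The change to compound 4 (`O=C(Nc1ccc2sc(-c3cccc(F)c3F)nc2c1)N1CCCC1`) reads fluoro in place of hydrogen on an aromatic carbon and in short it turns 2-fluorophenyl into 2,3-difluorophenyl. For the measured compounds named here, the one measured step is a step that the two limits leave unreadable from compound 2 to compound 3 and it puts piperidin-1-yl in place of pyrrolidin-1-yl on a carbonyl carbon, which is a different change from this one. Going by the values given here, no measured step swaps hydrogen for fluoro, so there is no measured size to carry over.

Compound 2 gives > 50 uM as a limit, and the expectation rests on that limit alone. The estimated change is a step that the limit leaves unreadable from compound 2 to compound 4 and it is expected to stay within the usual scatter, in neither direction. Another limit is the likeliest outcome in this assay for the new compound. Compound 4 is expected at 60 uM with an estimated range from 30 uM to 120 uM as its two ends.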

Compound 4, concentration for 90% of the maximal effect: > 50 uM
Compound 4 was reported as a limit (the forecaster's own chance of this, stated with the estimate: 85%); the middle value lies beyond the limit too.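

For the compounds shown here, compound 2 and compound 4 both sit at the same limit, so no step between them can be read, and the added fluoro gets no size: the limit of > 50 uM in this assay, at which 4 of the 4 values shown sit. The compounds shown leave open what number any of them would give in this assay, and so whether swapping hydrogen for fluoro changes that number at all.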